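Compound 4 against the shared core of compound 3

The compounds below may be only part of what the source reports. "The series", "measured", "known", "first", "only" and "open" are said of these compounds alone.

Compound 1 `CCCCCc1ccc2nc(N)sc2c1` and compound 2 `Nc1nc2ccc(CC(F)(F)F)cc2s1` carry a free amino group on the shared core. In a functional assay on the whole organism with Rattus norvegicus as the target (a higher number here means that more compound is needed for the effect, a lower number that less compound is needed), compound 1 gives 7.5 mg/kg. In this assay compound 2 gives 8 mg/kg. Among the compounds with values here, the single step between them, a 1.1-fold higher number from compound 1 to compound 2 (0.03 log units; within the scatter), is the only measured step, and it sits on a saturated chain carbon bound to an aromatic carbon, not at the place that is changed below. Compound 3 `COC(=O)Cn1c(=N)sc2cc(OC(F)(F)F)ccc21` is built differently, with a substituent on the ring nitrogen. For compound 3 this assay reports only a limit, > 10 mg/kg, so where compound 3 stands in number is not known; it shares this limit with the limit of > 10 mg/kg in this assay, at which 1 of the 3 values shown sits.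

Compound 4 `CCSCCn1c(=N)sc2cc(OC(F)(F)F)ccc21` is compound 3 with (ethylsulfanyl)methyl in place of methoxycarbonyl on a saturated chain carbon bound to an aromatic nitrogen. Within the data shown here, no measured step touches this place, and no measured step exchanges a methoxycarbonyl for an (ethylsulfanyl)methyl, so the measured steps give no size and no direction for the change, and the limit on compound 3 leaves the starting point open. The step that the limit leaves unreadable from compound 3 to compound 4 is therefore expected to be small, without a direction that can be named. For compound 4 in this assay the estimate is 12 mg/kg, with a range from 4 mg/kg to 35 mg/kg, and a limit rather than a number is expected to be the more likely outcome.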

Compound 4, dose for half-maximal effect: 2.2 mg/kg
For compound 4 the middle estimate is 5.5-fold (0.74 log units) above the measured one, and the stated range ends above it.
By their numbers in this assay, from the lowest: compound 4; then compounds 1 and 2 (each within the scatter of the next). At a limit, above all of these: compound 3.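

Within the data shown here, the exchange of methoxycarbonyl for (ethylsulfanyl)methyl on a saturated chain carbon bound to an aromatic nitrogen gives an at least 4.5-fold lower number from compound 3 to compound 4 (0.65 log units; beyond the scatter) in this assay, and this is the first measured step at this place. Among these compounds, the number in this assay therefore responds to what is carried here, whereas the only earlier step, a 1.1-fold higher number from compound 1 to compound 2 (0.03 log units; within the scatter), lay at a different place and showed no such response. The value of compound 3 is a limit, > 10 mg/kg, so the step gives a bound rather than a size: the limit of > 10 mg/kg in this assay, at which 1 of the 4 values shown sits.

The compounds shown do not separate the parts of this exchange, in which the two oxygen atoms and the double bond leave and a sulfur atom enters along with more carbon, so it remains open whether an ethoxy group in place of the ethylsulfanyl would give a similar number. They also leave open how a carboxylic acid, an amine or a longer chain would read at this place, and whether the lower number of compound 4 would hold with any group other than trifluoromethoxy on the shared core.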